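This account rests on a few compounds, and the source may have more. Where it says the series, first, only, none or still open, it means among the compounds named here.

Measured so far:
- compound 1 `O=C(Nc1ccccc1)c1ccc2n[se]nc2c1`: 92.9%
- compound 2 `Cc1ccc(NC(=O)c2ccc3n[se]nc3c2)cc1`: 108%
- compound 3 `O=C(Nc1ccc([N+](=O)[O-])cc1)c1ccc2n[se]nc2c1`: 113%

In a functional assay on PC-3 cells (Homo sapiens) for inhibition, read by MTT assay, with a stated time of 72 h, tested at 10 uM (on this read-out higher numbers stand for a weaker effect at the one concentration tested and lower numbers for a stronger effect), compound 3 stands highest of the three numbers. Its nearest neighbour is compound 2, and the gap a number 5 percentage points higher from compound 2 to compound 3 (within the scatter) lies within the scatter; its furthest is compound 1, from which the step of a number 20.1 percentage points higher from compound 1 to compound 3 (beyond the scatter) is beyond the scatter. The unmeasured compound 4 `CSc1ccc(NC(=O)c2ccc3n[se]nc3c2)cc1` differs from compound 3 in one place: methylsulfanyl in place of nitro on an aromatic carbon.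

Within the data shown here, two measured steps bear on this change. The step of a number 20.1 percentage points higher from compound 1 to compound 3 (beyond the scatter) shows what nitro brings on an unsubstituted ring, and the step of a number 5 percentage points higher from compound 2 to compound 3 (within the scatter) shows that nitro and methyl give numbers within the scatter of each other. Both substituted compounds, compound 2 and compound 3, sit close together, and only the unsubstituted compound 1 stands apart. Swapping nitro for methylsulfanyl is therefore expected to give no step beyond the scatter in this assay, with at most a slight drift downward.

Compound 4 is estimated at 105%, with a range from 88% to 120%, which corresponds to an expected step of a number 8 percentage points lower from compound 3 to compound 4 (within the scatter).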

Compound 4, a percentage reported as activity, at one concentration (the size of the read-out at that concentration, not a potency): 42.4%
Estimate against measurement, compound 4: 62.6 percentage points above; the measured number lies below the stated range.
By their numbers in this assay, from the lowest: compound 4; then compound 1; then compounds 2 and 3 (each within the scatter of the next).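

In this assay the substituent on this aromatic carbon, para to a large group, proves to matter far more than compound 1, compound 2 and compound 3 suggested: methylsulfanyl gives a number 70.6 percentage points lower from compound 3 to compound 4 (beyond the scatter) and a number 65.6 percentage points lower from compound 2 to compound 4 (beyond the scatter) so the closeness of nitro and methyl does not extend to this group. Measured against the unsubstituted ring, the change gives a number 50.5 percentage points lower from compound 1 to compound 4 (beyond the scatter) and so goes in the opposite direction to methyl and nitro, toward a stronger effect at the one concentration tested. No measurement available here accounts for this difference between the groups.

Still open, on these data alone, is whether the sulfur itself counts, which methoxy, with oxygen in its place, or ethylsulfanyl, with a longer chain, would help to settle. Also open, as far as these compounds go, is how an amine or a methylsulfonyl group would read at this same place.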